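This account rests on a few compounds, and the source may have more. Where it says the series, first, only, none or still open, it means among the compounds named here.

Measured compounds:

compound 1 `COc1ccc(Cl)c(-c2nnc3n2NC(c2ccc([N+](=O)[O-])o2)S3)c1` — in a functional assay on the whole organism (strain Wistar Albino) for inhibition, with Rattus norvegicus as the target, read by paw edema, with a stated time of 1 h, at a dose of 20 mg/kg (a higher number here means more inhibition at the dose given (going by the name of the read-out), a lower number less inhibition), compound 1 gives 15.6%
compound 2 `COc1ccc(Cc2nnc3n2NC(c2ccc([N+](=O)[O-])o2)S3)cc1OC` — in this assay compound 2 gives 14.5%
compound 3 `COc1ccc(Cl)c(-c2nnc3n2NC(c2ccc[nH]2)S3)c1` — in this assay compound 3 gives 12.8%

The three measured compounds share a fused two-ring core carrying a substituent on a saturated ring carbon. Compound 1 and compound 2 differ in more than one place, and the difference between their two cores is not broken down here; their values in this assay lie within the scatter of each other, as does the value of compound 3 relative to both. Compound 3 differs from compound 1 by one change, (1H-pyrrol-2-yl in place of 5-nitrofuran-2-yl on a saturated ring carbon), and this change gave a number 2.8 percentage points lower from compound 1 to compound 3 (within the scatter).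

Compound 4 `COc1ccc(Cc2nnc3n2NC(c2ccc[nH]2)S3)cc1OC` has not yet been measured. It differs from compound 2 by 1H-pyrrol-2-yl in place of 5-nitrofuran-2-yl on a saturated ring carbon, which is the same change as that from compound 1 to compound 3, at a place described in identical words. Within the data shown here, the only guide to its effect is therefore the single measured step from compound 1 to compound 3, which stayed within the scatter. Compound 4 is accordingly expected to show a step of about the same small size, a number 2.5 percentage points lower from compound 2 to compound 4 (within the scatter), because the step of a number 2.8 percentage points lower from compound 1 to compound 3 (within the scatter) was itself small. Among the measured compounds shown here, on this basis compound 4 is estimated to give 12% in this assay, with a likely range from 5% to 19%; the range is set wide because only one example of this change, a number 2.8 percentage points lower from compound 1 to compound 3 (within the scatter), is available.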

Compound 4, a percentage reported as inhibition, in the whole organism at one dose (the size of the read-out at that dose, not a potency): 13.2%
For compound 4 the middle estimate is 1.2 percentage points below the measured one; the measured number falls inside the stated range.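

On the core of compound 2, putting 1H-pyrrol-2-yl in place of 5-nitrofuran-2-yl on the saturated ring carbon gave, in this assay, a number 1.3 percentage points lower from compound 2 to compound 4 (within the scatter). Set beside the same change on the core of compound 1, the two steps agree: the same change on two cores in this assay, a number 2.8 percentage points lower (within the scatter) from compound 1 to compound 3 and a number 1.3 percentage points lower (within the scatter) from compound 2 to compound 4, 1.5 percentage points apart, within the scatter of two such steps. The change therefore carries from one core to the other in this limited sense: on both cores it leaves the number within the scatter, but neither step is large enough to show that one of the two groups is better than the other, and two cores say nothing about how the change would behave on a third.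

The compounds shown leave open whether any other group on the saturated ring carbon, such as an aliphatic amine, a carboxylic acid or a longer alkyl chain, would move the number in this assay beyond the scatter. They also leave open whether the two five-membered aromatic rings would stay this close at another dose or at another time after dosing, since all four values here come from a single dose and a single time.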